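A few compounds are considered here, and "the series" means these few. Any claim that something is new, unique, unknown or untested is made for them only; others in the source may bear on it.

Of the compounds shown here, two sharing one core have been measured in a functional assay on the whole organism (strain albino) for inhibition, with Rattus norvegicus as the target, read by paw edema, with stated times of 30 min and 4 h, at a dose of 100 mg/kg by the oral route; on this read-out higher numbers stand for more inhibition at the one dose given (going by the name of the read-out) and lower numbers for less inhibition. Compound 1 `O=C(COCc1c(-c2ccccc2)no[n+]1[O-])Nc1ccc(C(=O)/C=C/c2ccc(Cl)cc2)cc1` gives 75% in this assay, and compound 2 `COc1ccc(/C=C/C(=O)c2ccc(NC(=O)COCc3c(-c4ccccc4)no[n+]3[O-])cc2)cc1` gives 55%. For the measured compounds named here, the only step between them, a number 20 percentage points lower from compound 1 to compound 2 (beyond the scatter), comes with methoxy in place of chloro on an aromatic carbon, and on these two numbers compound 2 stands lowest, with compound 1 above it. Compound 3 `O=C(COCc1c(-c2ccccc2)no[n+]1[O-])Nc1ccc(C(=O)/C=C/c2ccco2)cc1` has not yet been measured in this assay. It differs from compound 2 by furan-2-yl in place of 4-methoxyphenyl on a double-bonded chain carbon bound to a double-bonded chain carbon. No measured step bears on this change: the single step shown exchanges one group on an aromatic carbon, whereas here the whole 4-methoxyphenyl leaves and furan-2-yl enters. With nothing to point either way, the expectation for compound 3 in this assay is a step of no change at the digits printed from compound 2 to compound 3 (within the scatter), one within the scatter. Compound 3 is estimated at 55%, in a range from 35% to 72%.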

Compound 3, a percentage reported as inhibition, in the whole organism at one dose (the size of the read-out at that dose, not a potency): 58%
Beside the measured number, compound 3's estimate is 3 percentage points below it, within the range that was stated.
By their numbers in this assay, from the lowest: compounds 2 and 3 (each within the scatter of the next); then compound 1.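

Furan-2-yl in place of 4-methoxyphenyl gives a number 3 percentage points higher from compound 2 to compound 3 (within the scatter) in this assay, so at this double-bonded chain carbon a five-membered aromatic ring with one hetero atom cannot be told apart from 4-methoxyphenyl on this read-out. The same furan-2-yl in place of 4-chlorophenyl gives a number 17 percentage points lower from compound 1 to compound 3 (beyond the scatter) and so, among the three groups at this place, only the 4-chlorophenyl of compound 1 stands clear of the other two. Nothing on hand gives a reason for these numbers.

The compounds shown leave open whether the higher number of compound 1 belongs to the chloro group itself or to the phenyl ring that carries it, which an unsubstituted phenyl, a 4-fluorophenyl or a 4-bromophenyl here would help to settle. They also leave open how a thiophen-2-yl or a pyridin-4-yl would read at this place.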